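This account rests on a few compounds, and the source may have more. Where it says the series, first, only, none or still open, it means among the compounds named here.

Among the measured compounds shown here, in a functional assay on MGC-803 cells (Homo sapiens) for inhibition, read by MTT assay, with a stated time of 72 h (on this read-out higher numbers stand for weaker inhibition and lower numbers for stronger inhibition), compound 3 `CN1CCN(C(=S)SCCCOc2ccc(C(=O)/C=C/c3ccc(Cl)cc3)cc2)CC1` gives 29400 nM, the second highest of the three numbers measured so far. Compound 1 `O=C(/C=C/c1ccc(Cl)cc1)c1ccc(OCCCSC(=S)N2CCCC2)cc1` gives 34500 nM, and compound 2 `O=C(/C=C/c1ccc(Cl)cc1)c1ccc(OCCSC(=S)N2CCCCC2)cc1` gives 12800 nM. The step of a 1.2-fold lower number from compound 1 to compound 3 (0.07 log units; within the scatter) shows that swapping one ring on the thiocarbonyl carbon for another left the number within the scatter, whereas a 2.7-fold lower number from compound 1 to compound 2 (0.43 log units; beyond the scatter) combined a ring change with a different chain and lies beyond the scatter. Compound 4 `O=C(/C=C/c1ccc(Cl)cc1)c1ccc(OCCCSC(=S)N2CCCCC2)cc1` carries piperidin-1-yl in place of 4-methylpiperazin-1-yl on a thiocarbonyl carbon. Since only the ring on the thiocarbonyl carbon changes here, the closest guide is the step from compound 1 to compound 3, and no shift beyond the scatter is expected. For compound 4 the estimated step is a 1.2-fold lower number from compound 3 to compound 4 (0.07 log units; within the scatter). Compound 4 is therefore expected to give 25000 nM, in a range from 10000 nM to 60000 nM.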

Compound 4, half-maximal inhibitory concentration: 56800 nM
Estimate against measurement, compound 4: 2.3-fold (0.36 log units) below; low and high end bracket the measured number.
By their numbers in this assay, from the lowest: compound 2; then compounds 3, 1 and 4 (each within the scatter of the next).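

Exchanging the ring on the thiocarbonyl carbon stays within the scatter in both ring steps, a 1.9-fold higher number from compound 3 to compound 4 (0.29 log units; within the scatter) and a 1.6-fold higher number from compound 1 to compound 4 (0.22 log units; within the scatter), so piperidin-1-yl, 4-methylpiperazin-1-yl and pyrrolidin-1-yl cannot be told apart on the chain these compounds share. Among the compounds shown here, with piperidin-1-yl kept, the chain change alone gives a 4.4-fold higher number from compound 2 to compound 4 (0.65 log units; beyond the scatter), a step beyond the scatter that the earlier compounds showed only mixed with a ring change. No evidence at hand explains this difference. As far as these compounds go, whether the chain step holds with other rings remains open, as does what a morpholine ring or a longer chain would give.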